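The compounds below may be only part of what the source reports. "The series", "measured", "known", "first", "only" and "open" are said of these compounds alone.

Measured in a functional assay on MDA-MB-453 cells (Homo sapiens) for antiproliferative activity; on this read-out lower numbers stand for stronger inhibition of growth and higher numbers for weaker inhibition of growth:
- compound 1 `CCCCCCNC(=O)c1cc(C#Cc2cc(OC)ccc2OC)ccc1OC`: > 100000 nM (a limit)
- compound 2 `CCCCCCNC(=O)c1cc(/C=C\c2cc(O)ccc2O)ccc1O`: 4500 nM

Compound 1 stands at a limit, > 100000 nM, and not at a number.

Compound 3 `COc1ccc(OC)c(C#Cc2ccc(OC)c(C(=O)O)c2)c1` keeps the core of compound 1 and differs from it as follows: hydroxy in place of hexylamino on a carbonyl carbon. This places hydroxy in place of hexylamino on a carbonyl carbon. For the measured compounds named here, no measured pair gives the size of this change. The estimated step that the limit leaves unreadable from compound 1 to compound 3 is none beyond the scatter in this assay, with inhibition of growth expected to stay weak. The estimated value for compound 3 is 130000 nM, with an expected range of 40000 nM to 400000 nM.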

Compound 3, concentration for 50% growth inhibition: 8800 nM
Beside the measured number, compound 3's estimate is 15-fold (1.17 log units) above it, outside the stated range (below it).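

Hydroxy in place of hexylamino on a carbonyl carbon gives an at least 11-fold lower number from compound 1 to compound 3 (1.05 log units; beyond the scatter) in this assay on the shared core. The hexylamino group is therefore not required at this place for measurable inhibition of growth, and the carboxy compound is the stronger of this pair. Compound 1 stands at a limit, so the step is a bound and not an exact size: the limit of > 100000 nM in this assay, at which 1 of the 3 values shown sits.

As far as these compounds go, whether a shorter chain, a primary amide or a methyl ester at this carbonyl carbon would match the carboxylic acid stays open. Compound 2 differs from compound 3 in more than one place, so the same change on its core cannot be read.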